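Sulfone to sulfide step on a weakly cytotoxic pair

A few compounds are considered here, and "the series" means these few. Any claim that something is new, unique, unknown or untested is made for them only; others in the source may bear on it.

Measured compounds:
compound 1, `CC(O)(CS(=O)(=O)c1ccccc1)c1nc(-c2ccccc2)no1` — > 100000 nM
compound 2, `CC(O)(CS(=O)(=O)c1ccc(Cl)cc1)c1nc(-c2ccc([N+](=O)[O-])c(C(F)(F)F)c2)no1` — 91000 nM

Going by the values given here, in a functional assay on DU-145 cells (Homo sapiens) for cytotoxicity, read by MTT assay (on this read-out higher numbers stand for weaker inhibition and lower numbers for stronger inhibition), compound 2 gives 91000 nM, the only actual number in the set. Compound 1 sits at the limit of > 100000 nM in this assay, at which 1 of the 2 values shown sits, so its entry > 100000 nM is a limit of the assay and not a number. Among the compounds with values here, no step between measured compounds differing in one place is available, so the size of any single change in this assay is unknown.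

Compound 3, `CC(O)(CSc1ccccc1)c1nc(-c2ccc([N+](=O)[O-])c(C(F)(F)F)c2)no1`, is the next compound to be measured. Relative to compound 2 the change is phenylsulfanyl in place of (4-chlorophenyl)sulfonyl on a saturated chain carbon, two bonds along the chain from an aromatic carbon and an oxygen on a saturated carbon. Within the data shown here, with no measured step to calibrate on, and compound 2 already weak, no step beyond the usual scatter is expected in this assay. Compound 3 is expected to give about 80000 nM, between 25000 nM and 250000 nM, an expected step of a 1.1-fold lower number from compound 2 to compound 3 (0.06 log units; within the scatter).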

Compound 3, half-maximal inhibitory concentration: 3000 nM
For compound 3 the middle estimate is 27-fold (1.43 log units) above the measured one; the whole stated range lies above it.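

In this assay, going by these compounds alone, this saturated chain carbon is the first place where a single-place change has a readable effect: a 30-fold lower number from compound 2 to compound 3 (1.48 log units; beyond the scatter). The change has two parts, since the sulfonyl gives way to a sulfanyl and the chlorine of the (4-chlorophenyl)sulfonyl group leaves with it, so neither part can be credited alone. No measurement shown accounts for the size of the step.

Still open, on these data alone, is which part carries the step; 4-chlorophenylsulfanyl and phenylsulfonyl on the core of compound 3 would separate the two. Also open, as far as these compounds go, is how this assay would read with a benzylsulfanyl group or an amine at this carbon.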